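Fluoro to methylsulfanyl at the aromatic carbon

The compounds below may be only part of what the source reports. "The series", "measured", "known", "first", "only" and "open" are said of these compounds alone.

In a functional assay on NCI-H520 cells (Homo sapiens) for cytotoxicity (on this read-out higher numbers stand for weaker inhibition of growth and lower numbers for stronger inhibition of growth), compound 1 (`CSc1ccc(C2=C(c3ccc(OCC4CO4)cc3)C(=O)N3CCCC3C2)cc1`) gives 30 nM and compound 2 (`CSc1ccc(C2=C(c3ccc(F)cc3)C(=O)N3CCCC3C2)cc1`) gives 250 nM. Within the data shown here, compound 2 therefore holds the higher of only two numbers, which means the weaker inhibition of growth. Among the measured compounds shown here, the single measured step, an 8.3-fold higher number from compound 1 to compound 2 (0.92 log units; beyond the scatter), is fluoro in place of (oxiran-2-yl)methoxy on an aromatic carbon.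

Compound 3 (`CSc1ccc(C2=C(c3ccc(SC)cc3)C(=O)N3CCCC3C2)cc1`) keeps the core of compound 2 and carries methylsulfanyl in place of fluoro on an aromatic carbon, para to a large group (methylsulfanyl in place of fluoro on an aromatic carbon). This is the same place that changed in the measured step, but no methylsulfanyl has yet been measured there, so the evidence is thin. The measured step shows that the number can move with the group at this place. Compound 2 also sits at the upper of the two values, so a shift towards a lower number is expected, smaller than the measured step but with wide uncertainty. The estimated step is a 2.3-fold lower number from compound 2 to compound 3 (0.36 log units; beyond the scatter). Compound 3 is expected at about 110 nM, with an estimated range of 35 nM to 350 nM.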

Compound 3, concentration for 50% growth inhibition: 15000 nM
For compound 3 the middle estimate is 140-fold (2.13 log units) below the measured one; the whole stated range lies below it.
By their numbers in this assay, from the lowest: compound 1; then compound 2; then compound 3.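

At the aromatic carbon para to a large group, the choice of group matters more than the first pair could show: in this assay, methylsulfanyl in place of fluoro gives a 60-fold higher number from compound 2 to compound 3 (1.78 log units; beyond the scatter), a larger move than an 8.3-fold higher number from compound 1 to compound 2 (0.92 log units; beyond the scatter), for a swap of only a small group. Methylsulfanyl in place of (oxiran-2-yl)methoxy gives a 500-fold higher number from compound 1 to compound 3 (2.70 log units; beyond the scatter), so with the rest of the structure unchanged, this one position now orders the series from (oxiran-2-yl)methoxy through fluoro to methylsulfanyl, from the lowest number to the highest. Nothing available bears on what lies behind this steep rise with methylsulfanyl.

Still open, on these data alone, is whether the low number of compound 1, at 30 nM, belongs to the oxirane ring or simply to an oxygen-linked chain at this place, a question that a plain methoxy group or a dihydroxypropoxy chain would help to separate. Also open, as far as these compounds go, is how an amine or a carboxylic acid would behave at this carbon, and what the methylsulfanyl group kept elsewhere on the shared core contributes.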